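Benzyl in Place of Trifluoromethyl: Expected Cytotoxicity

The source may hold more compounds than are shown below. What is called first, only, known or untested is meant among the compounds shown, and "the series" means these compounds.

Compound 1 `O=[N+]([O-])c1cn2c(n1)S(=O)(=O)CC(OCc1ccc(OC(F)(F)F)cc1)C2`, in an ADME assay on MRC5 cells (Homo sapiens) for cytotoxicity; on this read-out higher numbers stand for weaker inhibition and lower numbers for stronger inhibition: > 64000 nM, a limit of the assay rather than a number.
Compound 2 `O=[N+]([O-])c1cn2c(n1)S(=O)(=O)CC(Oc1ccc(OC(F)(F)F)cc1)C2`, in this assay: > 64000 nM, likewise a limit.

Compound 1 therefore stands at the limit of > 64000 nM in this assay, at which 2 of the 2 values shown sit, with no exact number known for it. Compound 3 `O=[N+]([O-])c1cn2c(n1)S(=O)(=O)CC(OCc1ccc(OCc3ccccc3)cc1)C2` differs from compound 1 in one place: benzyl in place of trifluoromethyl on an oxygen on an aromatic ring. Within the data shown here, no measured step matches this change, so in this assay no shift beyond the scatter is expected in either direction. Compound 3 is expected to give about 64000 nM, between 20000 nM and 150000 nM. The expected step of a number no higher from compound 1 to compound 3 (the limit leaves the size open) is estimated to be small.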

Compound 3, half-maximal inhibitory concentration: > 64000 nM
Compound 3: a limit, no number (the forecaster's own chance of this, stated with the estimate: 80%); the middle value sits exactly at the limit.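

Compound 1 and compound 3 both stand at a limit, so no step between them can be read: the limit of > 64000 nM in this assay, at which 3 of the 3 values shown sit.

The compounds shown leave open whether benzyl in place of trifluoromethyl changes the exact value in this assay at all.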